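The source may report more compounds than this note shows. Statements on the series, on what has been measured and on what is new or still open speak of the compounds shown alone.

Measured compounds:
Compound 1 `NS(=O)(=O)c1cc(-c2nnc(CN3CCN(c4ccc(F)cc4)CC3)o2)c(Cl)cc1SCc1ccccc1`: 10000 nM
Compound 2 `NCc1nnc(-c2cc(S(N)(=O)=O)c(SCc3ccccc3)cc2Cl)o1`: 490000 nM

In a functional assay on HeLa cells (Homo sapiens) for cytotoxicity, read by MTT assay, with a stated time of 72 h (on this read-out lower numbers stand for stronger inhibition and higher numbers for weaker inhibition), compound 2 gives the higher of the two numbers, and the gap to compound 1 lies beyond the scatter. Compound 3 `NS(=O)(=O)c1cc(-c2nnc(/C=C/c3c(Cl)cccc3Cl)o2)c(Cl)cc1SCc1ccccc1` is not yet measured. It differs from compound 2 by 2-(2,6-dichlorophenyl)ethenyl in place of aminomethyl on an aromatic carbon. With compound 1 showing 10000 nM and compound 2 showing 490000 nM, a large group in that place goes with the lower number, so the step from compound 2 to compound 3 is expected to be a sizeable drop in a 25-fold lower number from compound 2 to compound 3 (1.39 log units; beyond the scatter). Compound 3 is estimated at 20000 nM, within 3000 nM to 150000 nM.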

Compound 3, half-maximal inhibitory concentration: 12000 nM
Compound 3: the middle estimate sits 1.7-fold (0.22 log units) above what was measured, and the stated range covers the measured number.
By their numbers in this assay, from the lowest: compounds 1 and 3 (each within the scatter of the next); then compound 2.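

At this place on the five-membered aromatic ring, 2-(2,6-dichlorophenyl)ethenyl in place of aminomethyl gives, in this assay, a 41-fold lower number from compound 2 to compound 3 (1.61 log units; beyond the scatter). Compound 3 lies within the scatter of compound 1, so among these compounds a large group with no nitrogen and no hydrogen-bond donor goes with the same low range as the large group of compound 1. Nothing here gives a reason for this step. From the compounds shown here alone, it remains open whether the chlorine atoms or the ethenyl link matter, and whether a plain phenyl or a small methyl in that place would give a number nearer compound 2 or compound 3.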